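This account rests on a few compounds, and the source may have more. Where it says the series, first, only, none or still open, it means among the compounds named here.

Measured so far:

Compound 1 `O=S(=O)(NCCCCNCc1ccc(Br)cc1)c1cc(C(F)(F)F)cc(C(F)(F)F)c1` — 1700 nM
Compound 2 `O=S(=O)(NCCCNCc1ccc(Cl)c(Cl)c1)c1cc(C(F)(F)F)cc(C(F)(F)F)c1` — 1400 nM

In a functional assay on BXPC-3 cells (Homo sapiens) for inhibition, read by MTT assay, with a stated time of 72 h (on this read-out lower numbers stand for stronger inhibition of growth and higher numbers for weaker inhibition of growth), compound 2 gives 1400 nM, and compound 1 gives 1700 nM; the two numbers lie within the usual scatter of each other, so neither compound is set apart. Compound 3 `O=S(=O)(NCCCNCc1ccc(C(F)(F)F)cc1)c1cc(C(F)(F)F)cc(C(F)(F)F)c1` has not yet been measured. It differs from compound 2 by 4-(trifluoromethyl)phenyl in place of 3,4-dichlorophenyl on a saturated chain carbon bound to an amine nitrogen. Among the compounds with values here, only one measured step speaks to a swap of the aryl group on that chain carbon: a 1.2-fold lower number from compound 1 to compound 2 (0.08 log units; within the scatter), which also altered the chain and still stayed within the scatter. On that basis the change to compound 3 is expected to bring no step beyond the scatter, namely a 1.1-fold higher number from compound 2 to compound 3 (0.03 log units; within the scatter). Within the data shown here, compound 3 is therefore estimated at 1500 nM in this assay, with a range from 600 nM to 4000 nM reflecting the single supporting step.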

Compound 3, concentration for 50% growth inhibition: 1700 nM
Compound 3: middle estimate off by 1.1-fold (0.05 log units), on the low side, within the range that was stated.
By their numbers in this assay, from the lowest: compounds 2, 1 and 3 (each within the scatter of the next).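

In this assay, replacing 3,4-dichlorophenyl with 4-(trifluoromethyl)phenyl on a saturated chain carbon bound to an amine nitrogen gives a 1.2-fold higher number from compound 2 to compound 3 (0.08 log units; within the scatter) and keeps the two compounds within the scatter of each other. Within the data shown here, the earlier step also altered the chain, so this is the first step in which only the aryl group differs. It shows that this swap alone brings no difference that can be told from the scatter, though no measurement at hand bears on the reason for this result.

All three aryl groups shown carry bromine, chlorine or trifluoromethyl, so it remains open how a phenyl bearing a methoxy group or an amine would read here. Among these compounds, the effect of chain length alone also remains open, since the only step that alters the chain changes the aryl group as well.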